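This account rests on a few compounds, and the source may have more. Where it says the series, first, only, none or still open, it means among the compounds named here.

Measured so far:
compound 1, `C=CC(=O)Nc1cc(Nc2ncc(Cl)c(Nc3ccccc3S(=O)(=O)C(C)C)n2)c(OC)cc1N1CCN(S(C)(=O)=O)CC1`: 40 nM
compound 2, `C=CC(=O)Nc1cc(Nc2ncc(Cl)c(Nc3ccccc3S(=O)(=O)C(C)C)n2)c(OC)cc1N1CCN(C)CC1`: 43 nM

Both numbers come from a functional assay on NCI-H1975 cells (Homo sapiens) for inhibition, read by CellTiter-Glo, with a stated time of 72 h; on this read-out higher numbers stand for weaker inhibition of growth and lower numbers for stronger inhibition of growth. Among the compounds with values here, compound 2 stands within the scatter of compound 1, the only other number in this assay; the one measured step, a 1.1-fold higher number from compound 1 to compound 2 (0.03 log units; within the scatter), exchanges the substituent on the ring amine nitrogen and does not move the read-out beyond the scatter.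

Compound 3, `C=CC(=O)Nc1cc(Nc2ncc(Cl)c(Nc3ccccc3S(=O)(=O)C(C)C)n2)c(OC)cc1N1CCCN(C)CC1`, is the next compound to be measured. It differs from compound 2 by 4-methyl-1,4-diazepan-1-yl in place of 4-methylpiperazin-1-yl on an aromatic carbon. Within the data shown here, no measured step changes the size of this ring, so the only step that bears on the change is a 1.1-fold higher number from compound 1 to compound 2 (0.03 log units; within the scatter), which alters the same ring at its amine nitrogen and lies within the scatter. That step shows the ring tolerating a change without a shift in this assay. On that basis the expected step of a 1.2-fold higher number from compound 2 to compound 3 (0.07 log units; within the scatter) is none beyond the scatter, with wider uncertainty than a repeat measurement because the ring itself is altered. Compound 3 is expected to give about 50 nM, within a range from 20 nM to 130 nM.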

Compound 3, concentration for 50% growth inhibition: 15 nM
For compound 3 the middle estimate is 3.3-fold (0.52 log units) above the measured one; the measured number lies below the stated range.
By their numbers in this assay, from the lowest: compound 3; then compounds 1 and 2 (each within the scatter of the next).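

In this assay, within the data shown here, the change at the aromatic carbon ortho to the (vinylcarbonyl)amino group now moves the read-out: 4-methyl-1,4-diazepan-1-yl in place of 4-methylpiperazin-1-yl gives a 2.9-fold lower number from compound 2 to compound 3 (0.46 log units; beyond the scatter) and is the first step here to lie beyond the scatter, whereas the exchange on the ring amine nitrogen, a 1.1-fold higher number from compound 1 to compound 2 (0.03 log units; within the scatter), did not. The seven-membered ring also stands apart from the sulfonylated six-membered ring, with 4-methyl-1,4-diazepan-1-yl in place of 4-(methylsulfonyl)piperazin-1-yl giving a 2.7-fold lower number from compound 1 to compound 3 (0.43 log units; beyond the scatter), so at this position a change in ring size shifts the number where the change of nitrogen substituent on the six-membered ring did not, though the shift is modest and the direct ring-size comparison rests on a single pair. Nothing measured gives a cause for this shift.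

The compounds shown leave open whether the seven-membered ring keeps its lower number with methylsulfonyl, acetyl or a free secondary amine on its nitrogen in place of methyl. They also leave open how an open-chain group such as a dimethylaminoethylamino chain would compare at this carbon.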